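Moving Two Halogens onto the Benzyl Group

The compounds below may be only part of what the source reports. "The series", "measured", "known", "first", "only" and "open" are said of these compounds alone.

Of the compounds shown here, three built on a shared core have been measured in a functional assay on MGC-803 cells (Homo sapiens) for cytotoxicity, read by MTT assay, with a stated time of 2 days; a higher number here means a weaker inhibitor, a lower number a stronger inhibitor. Compound 1 `c1ccc(CO/N=C2/C(c3c[nH]c4ccccc34)=Nc3ccccc32)cc1` gives 15400 nM, the lowest of the three numbers, although its gap to compound 2 is within the scatter. Compound 2 `Cc1ccc(CO/N=C2/C(c3c[nH]c4ccc(F)cc34)=Nc3ccc(F)cc32)cc1` gives 20800 nM, and compound 3 `Cc1ccc(CO/N=C2/C(c3c[nH]c4ccc(Br)cc34)=Nc3ccc(Br)cc32)cc1` gives 31200 nM, a gap to compound 1 that lies beyond the scatter. For the measured compounds named here, compounds 2 and 3 each differ from compound 1 in more than one place, so no single step between measured compounds can be read off; their halogens sit on the core rather than on the benzyl group.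

Compound 4 `Fc1ccc(CO/N=C2/C(c3c[nH]c4ccccc34)=Nc3ccccc32)c(Cl)c1` has not yet been measured. It departs from compound 1 by one change: 2-chloro-4-fluorophenyl in place of phenyl on a saturated chain carbon bound to an oxygen on an unsaturated carbon. Going by the values given here, no measured pair isolates this change, so its size is unknown here. Among the compounds with values here, the three numbers so far sit close together, and the halogens of compounds 2 and 3 at other places moved the number only modestly. Compound 4 is therefore expected to stay near compound 1, with a step of a 1.2-fold lower number from compound 1 to compound 4 (0.07 log units; within the scatter) not expected to reach beyond the scatter. The estimate for compound 4 is 13000 nM, within an expected range from 5000 nM to 35000 nM.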

Compound 4, half-maximal inhibitory concentration: 18500 nM
Compound 4: middle estimate off by 1.4-fold (0.15 log units), on the low side; measured number inside the range.
By their numbers in this assay, from the lowest: compounds 1, 4, 2 and 3 (each within the scatter of the next, the first and the last beyond it).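

In this assay, putting 2-chloro-4-fluorophenyl in place of phenyl on a saturated chain carbon bound to an oxygen on an unsaturated carbon gives a 1.2-fold higher number from compound 1 to compound 4 (0.08 log units; within the scatter), the first step among these compounds that isolates a change at this position. It shows that adding these two halogens to the benzyl group, with the ring itself kept and no hydrogen-bond donor or acceptor counted on either group, does not carry the number beyond the usual scatter of this kind of measurement. No measurement offered here accounts for the size of this step.

The two halogens entered as one change, so the compounds shown cannot separate what the chlorine and the fluorine each contribute, or say whether either alone would give a different number. They also leave open whether an amine or a carboxylic acid on the phenyl ring, or a longer chain in place of the benzyl group, would move the number beyond the scatter at this same position.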